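A few compounds are considered here, and "the series" means these few. Any claim that something is new, unique, unknown or untested is made for them only; others in the source may bear on it.

Measured compounds:
- compound 1 `CN(c1ccc2cc(NC(=O)CCc3ccc(C(F)(F)F)cc3)ccc2n1)C1CCCCC1`, in an assay on isolated protein for displacement of a labelled ligand from melanin-concentrating hormone receptor 1 (Homo sapiens) (a higher number here means a weaker inhibitor, a lower number a stronger inhibitor), compound 1 gives 18 nM
- compound 2 `CC1CCCN1c1ccc2cc(NC(=O)CCc3ccc(C(F)(F)F)cc3)ccc2n1`, compound 2 gives 5 nM
- compound 3 `CN(c1ccc2cc(NC(=O)CCc3ccc(C(F)(F)F)cc3)ccc2n1)C1CCCC1`, compound 3 gives 2 nM

Compound 3 holds the lowest number of the three; compound 2 sits nearest, compound 1 furthest, both steps beyond the scatter. The steps within the set run a 9.0-fold lower number from compound 1 to compound 3 (0.95 log units; beyond the scatter), a 3.6-fold lower number from compound 1 to compound 2 (0.56 log units; beyond the scatter) and a 2.5-fold lower number from compound 2 to compound 3 (0.40 log units; beyond the scatter), all modest in size.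

Compound 4 `O=C(CCc1ccc(C(F)(F)F)cc1)Nc1ccc2nc(N3CCCCCC3)ccc2c1` is the next entry. It differs from compound 3 in the group on the aromatic carbon: azepan-1-yl in place of cyclopentyl(methyl)amino on an aromatic carbon. The two have the same atoms, joined differently. Two measured steps speak to this change. The cyclopentyl(methyl)amino of compound 3 against the 2-methylpyrrolidin-1-yl of compound 2 shows a 2.5-fold lower number from compound 2 to compound 3 (0.40 log units; beyond the scatter); the cyclohexyl(methyl)amino of compound 1 against compound 3 shows a 9.0-fold lower number from compound 1 to compound 3 (0.95 log units; beyond the scatter). Both point to a higher number when the group on this carbon is changed away from that of compound 3, and the azepan-1-yl of compound 4 resembles neither of them closely. A modest upward step is therefore expected, of the order of a 3.0-fold higher number from compound 3 to compound 4 (0.48 log units; beyond the scatter). Compound 4 is estimated at 6 nM, within 2 nM to 20 nM.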

Compound 4, half-maximal inhibitory concentration: 36 nM
Compound 4: the middle estimate sits 6.0-fold (0.78 log units) below what was measured; measured number outside the range, above it.
By their numbers in this assay, from the lowest: compound 3; then compound 2; then compounds 1 and 4 (each within the scatter of the next).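

Rearranging the same atoms into the azepan-1-yl group gives the only large step in the set, an 18-fold higher number from compound 3 to compound 4 (1.26 log units; beyond the scatter), in this assay, so at this aromatic carbon the way the atoms are joined matters as much as which atoms are present. Holding the nitrogen in a ring does not alone account for this, as compound 2 also carries its nitrogen in a ring and the step is still a 7.2-fold higher number from compound 2 to compound 4 (0.86 log units; beyond the scatter), while a 2.0-fold higher number from compound 1 to compound 4 (0.30 log units; within the scatter) leaves compound 1 and compound 4 not separated, although only compound 4 has the ring nitrogen. No measurement at hand accounts for the gap between compound 3 and compound 4.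

Open, going by these compounds, is where an unsubstituted pyrrolidin-1-yl or a piperidin-1-yl would fall in this assay. Also open, on these data alone, is whether a cyclobutyl on the nitrogen would extend the gain seen from cyclohexyl to cyclopentyl.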